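Swapping trifluoromethyl for hydroxy on a chalcone side ring

This account rests on a few compounds, and the source may have more. Where it says the series, first, only, none or still open, it means among the compounds named here.

Measured compounds:
compound 1, `COc1cc(OC)c(OC)cc1/C=C/C(=O)c1ccc(OC)c2c1OC(C)(C)C=C2`, > 10000 nM
compound 2, `COc1ccc(C(=O)/C=C/c2ccc(OC)c(OC)c2OC)c2c1C=CC(C)(C)O2`, > 10000 nM
compound 3, `COc1ccc(C(=O)/C=C/c2cccc(C(F)(F)F)c2)c2c1C=CC(C)(C)O2`, 7850 nM

All three share the same core and were tested in a functional assay on K562 cells (Homo sapiens) for antiproliferative activity, read by MTT assay, with a stated time of 24 h; a lower number here means a stronger inhibitor, a higher number a weaker inhibitor. Compound 1 reaches only a limit of the assay, > 10000 nM. Compound 2 likewise stops at a limit, > 10000 nM. Within the data shown here, compound 3 is the only one with a number, 7850 nM, while the other two sit at the limit of > 10000 nM in this assay, at which 2 of the 3 values shown sit. Even so, compound 3 is a weak inhibitor in this assay.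

Compound 4, `COc1ccc(C(=O)/C=C/c2cccc(O)c2)c2c1C=CC(C)(C)O2`, has not yet been measured. It differs from compound 3 in one place: hydroxy in place of trifluoromethyl on an aromatic carbon. Among the measured compounds shown here, no pair of measured compounds differs in a single place, so no measured step shows how this change plays out. The hydroxy group brings one hydrogen-bond donor and one acceptor where trifluoromethyl carried none, but nothing here says what that does to potency. The step is expected to be a 1.1-fold lower number from compound 3 to compound 4 (0.05 log units; within the scatter), within the usual scatter. In this assay compound 4 is estimated at 7000 nM, with a range from 2500 nM to 20000 nM.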

Compound 4, half-maximal inhibitory concentration: > 10000 nM
Compound 4 was reported as a limit; the forecaster's own chance of this, stated with the estimate: 35%; middle value at least 1.4-fold (0.15 log units) away from the limit.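

Among these compounds, the step from trifluoromethyl to hydroxy is the first single change that can be read, and in this assay it comes to an at least 1.2-fold higher number from compound 3 to compound 4 (0.10 log units; that floor lies within the scatter). This is only a floor and not a measured size, so the real gap between the two compounds could be small or large. Still, the hydrogen-bond donor and acceptor that hydroxy brings to this aromatic carbon yield no visible gain in potency, and the series still offers a single number to compare against, while the rest of its values stop at one limit: the limit of > 10000 nM in this assay, at which 3 of the 4 values shown sit.

Going by these compounds, how far compound 4 really lies beyond that limit stays open, so neither the size of this step nor the true ranking of the two groups can be settled from these values. Also open, on these data alone, is whether an amine or a carboxylic acid on the same aromatic carbon would bring the number well below the limit, or whether the potency in these cells stays weak whatever sits there.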